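The compounds below may be only part of what the source reports. "The series", "measured", "known", "first", "only" and "open" are said of these compounds alone.

Compound 2 `C[C@@H](O)[C@H]1C(=O)N2C(C(=O)OCOC(=O)O[C@H]3CCc4ccccc43)=C(S[C@@H]3CN[C@H](C(=O)N(C)C)C3)[C@H](C)[C@H]12` sits at the limit of < 0.0167 h in this assay, at which 1 of the 2 values shown sits: in a physicochemical assay for metabolic stability, read by HPLC, at pH 7.4, tested at 100 uM (a higher number here means that the compound lasts longer, a lower number that the compound disappears faster), compound 2 gives < 0.0167 h, which is a limit of the assay rather than a number. Compound 3 `C[C@@H](O)[C@H]1C(=O)N2C(C(=O)OCOC(=O)O[C@@H]3CCCCc4ccccc43)=C(S[C@@H]3CN[C@H](C(=O)N(C)C)C3)[C@H](C)[C@H]12` differs from it by a group of 11 heavy atoms (11 carbon; one six-membered aromatic ring of carbon only, one seven-membered non-aromatic ring of carbon only) in place of a group of 9 heavy atoms (9 carbon; one five-membered non-aromatic ring of carbon only, one six-membered aromatic ring of carbon only), on an oxygen next to a carbonyl group. Among the compounds with values here, one measured step bears on this change, in the opposite direction: an at least 27-fold lower number from compound 1 to compound 2 (1.44 log units; beyond the scatter). In this assay compound 1 `C[C@@H](O)[C@H]1C(=O)N2C(C(=O)OCOC(=O)O[C@H]3CCCCc4ccccc43)=C(S[C@@H]3CN[C@H](C(=O)N(C)C)C3)[C@H](C)[C@H]12` gives 0.467 h. Reversing that ring swap is expected to give a large rise in this assay, namely an at least 23-fold higher number from compound 2 to compound 3 (1.37 log units; beyond the scatter). Compound 3 is therefore estimated at 0.4 h, most likely between 0.1 h and 1.5 h.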

Compound 3, half-life: 0.45 h
The estimate for compound 3 lay 1.1-fold (0.05 log units) below the measured number; measured number inside the range.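

The ring swap on an oxygen next to a carbonyl group gives an at least 26-fold higher number from compound 2 to compound 3 (1.43 log units; beyond the scatter) in this assay again, now with the other drawn configuration of the larger group. Compound 2 gives < 0.0167 h here, which is a limit of the assay and not a number. What is new concerns the stereocentre, drawn S in compound 1 and R in compound 3: the pair shows a 1.0-fold lower number from compound 1 to compound 3 (0.02 log units; within the scatter) here, so the seven-membered ring group reads alike in both forms. From the compounds shown here alone, whether the 2,3-dihydro-1H-inden-1-yl group also reads alike in both forms stays open, as does how a group carrying an amine would behave on this oxygen.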